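Chain-end ester replaces alkyl terminus in thioether series

The compounds below may be only part of what the source reports. "The series", "measured", "known", "first", "only" and "open" are said of these compounds alone.

Measured so far:
Compound 1, `CCCOc1ccc(NC(=O)CCCCCCCSc2nnc(Cc3nn(C)c(=O)c4ccccc34)n2C)cc1`: in an assay on isolated protein (Mus musculus) for inhibition of IL15-IL15 receptor (Homo sapiens), read by resazurin assay, with stated times of 30 min and 2.5 days (a lower number here means a stronger inhibitor, a higher number a weaker inhibitor), compound 1 gives 1600 nM.
Compound 2, `CCCCCCCCCCSc1nnc(Cc2nn(C)c(=O)c3ccccc23)n1C`: in this assay compound 2 gives 7600 nM.

Compound 2 stands at the highest number of the two measured. Its nearest neighbour is compound 1, which sits at a lower number, and that gap lies beyond the usual scatter. Among the compounds with values here, no pair of measured compounds differs in a single place, so no measured step exists for any one change.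

Compound 3, `Cn1c(Cc2nn(C)c(=O)c3ccccc23)nnc1SCCCCCCCC(=O)Oc1ccc(Cl)cc1Cl`, is derived from compound 2 by one alteration: (2,4-dichlorophenoxy)carbonyl in place of propyl on a saturated chain carbon, seven bonds along the chain from a sulfur. Nothing measured isolates this change. What the two measured values do show is that compound 1 and compound 2 both carry the same core and the same thioether chain, and compound 1 gives the lower number.

For this assay a step toward a lower number, beyond the scatter, is expected; the estimated step is a 3.0-fold lower number from compound 2 to compound 3 (0.48 log units; beyond the scatter). Compound 3 is estimated at 2500 nM, with a range from 700 nM to 9000 nM.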

Compound 3, half-maximal inhibitory concentration: 800 nM
Compound 3: middle estimate off by 3.1-fold (0.49 log units), on the high side; measured number inside the range.
By their numbers in this assay, from the lowest: compounds 3 and 1 (each within the scatter of the next); then compound 2.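

In this assay, within the data shown here, (2,4-dichlorophenoxy)carbonyl in place of propyl on a saturated chain carbon, seven bonds along the chain from a sulfur, gives a 9.5-fold lower number from compound 2 to compound 3 (0.98 log units; beyond the scatter) and so provides the first single-place step at this chain end. The change from the alkyl terminus registers beyond the scatter. With 2,4-dichlorophenoxy in place of (4-propoxyphenyl)amino on a carbonyl carbon, the step reads a 2.0-fold lower number from compound 1 to compound 3 (0.30 log units; within the scatter) and so does not separate the ester of compound 3 from the amide of compound 1. No measurement bearing on the cause of either step is at hand.

Whether the carbonyl alone or the aryl ring accounts for the step remains open, and a carboxylic acid or a methyl ester at the chain end would separate the two. As far as these compounds go, the role of the two chlorines also remains open, as an unsubstituted phenyl ester would show.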